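This account rests on a few compounds, and the source may have more. Where it says the series, first, only, none or still open, it means among the compounds named here.

Of the compounds shown here, three sharing one core have been measured so far in a functional assay on TM4 cells (Mus musculus) for cytotoxicity, read by MTT assay, with a stated time of 72 h; on this read-out lower numbers stand for stronger inhibition and higher numbers for weaker inhibition. Compound 1 (`Nc1nc(Nc2ccc(S(N)(=O)=O)cc2)sc1C(=O)c1cccnc1`) carries pyridin-3-yl on the carbonyl carbon and gives 13000 nM there. Compound 2 (`Nc1nc(Nc2ccc(S(N)(=O)=O)cc2)sc1C(=O)c1cccc(F)c1`) carries 3-fluorophenyl in that place and gives 4800 nM, while compound 3 (`Nc1nc(Nc2ccc(S(N)(=O)=O)cc2)sc1C(=O)c1cccc([N+](=O)[O-])c1`) carries 3-nitrophenyl and gives 4000 nM. Compound 3 therefore sits at the low end of these numbers, level with one neighbour (a 1.2-fold lower number from compound 2 to compound 3 (0.08 log units; within the scatter)) and clear of the other (a 3.3-fold lower number from compound 1 to compound 3 (0.51 log units; beyond the scatter)). The other move away from pyridin-3-yl was similarly modest (a 2.7-fold lower number from compound 1 to compound 2 (0.43 log units; beyond the scatter)).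

Compound 4 (`Nc1nc(Nc2ccc(S(N)(=O)=O)cc2)sc1C(=O)c1ccccc1`) is the plain phenyl version, with hydrogen in place of nitro on an aromatic carbon. The nearest guide is the swap of fluoro for nitro at this same place, which stayed within the scatter, although neither group is hydrogen. In this assay a small rise is therefore expected, probably no larger than the scatter. The expected change is a 1.4-fold higher number from compound 3 to compound 4 (0.14 log units; within the scatter) in size. For compound 4 the estimated value is 5500 nM, with an expected range of 2500 nM to 12000 nM.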

Compound 4, half-maximal inhibitory concentration: 9100 nM
Compound 4: the middle estimate sits 1.7-fold (0.22 log units) below what was measured; the measured number falls inside the stated range.
By their numbers in this assay, from the lowest: compounds 3, 2, 4 and 1 (each within the scatter of the next, the first and the last beyond it).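

In this assay, taking the nitro group off the ring gives a step beyond the scatter (a 2.3-fold higher number from compound 3 to compound 4 (0.36 log units; beyond the scatter)), so a group at this place can shift the number, while taking off fluoro stays within the scatter (a 1.9-fold higher number from compound 2 to compound 4 (0.28 log units; within the scatter)). The plain phenyl ring also stays within the scatter of pyridin-3-yl (a 1.4-fold lower number from compound 1 to compound 4 (0.15 log units; within the scatter)), so among these compounds the clear separation from compound 1 belongs to compound 3 and compound 2, which carry a group on the ring, and not to compound 4. Nothing available explains why nitro and hydrogen differ here.

As far as these compounds go, whether an amine or a carboxylic acid at this place would give a lower or a higher number remains open. So does how nitro or fluoro would behave elsewhere on the ring.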